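Trimming the benzyl sulfide: from compound 1 to compound 4

The compounds below may be only part of what the source reports. "The series", "measured", "known", "first", "only" and "open" are said of these compounds alone.

Compound 1 `Cc1cc(Nc2cc(-c3ccccc3)[nH]n2)n2nc(SCc3c(Cl)cccc3Cl)nc2n1` gives 39600 nM in an ADME assay on GES1 cells (Homo sapiens) for inhibition, read by MTT assay, with a stated time of 72 h (on this read-out lower numbers stand for stronger inhibition and higher numbers for weaker inhibition), the highest of the two numbers available, while compound 2 `Cc1cc(Nc2ccn(Cc3nc(C)c4ccccc4n3)n2)n2nc(SCc3ccc(Br)cc3)nc2n1` gives 36800 nM, within the scatter of it. Compound 3 `Cc1cc(Nc2cc(-c3ccccc3)[nH]n2)n2nc(SCC3CC3)nc2n1` reaches only the limit > 50000 nM in this assay. Compound 4 `C=CCSc1nc2nc(C)cc(Nc3cc(-c4ccccc4)[nH]n3)n2n1` differs from compound 1 by vinyl in place of 2,6-dichlorophenyl on a saturated chain carbon bound to a sulfur. For the measured compounds named here, the one comparable step is the move to cyclopropyl, an at least 1.2-fold higher number from compound 1 to compound 3 (0.10 log units; that floor lies within the scatter), which ran into the limit (the limit of > 50000 nM in this assay, at which 1 of the 3 values shown sits). With another small group replacing 2,6-dichlorophenyl on a saturated chain carbon bound to a sulfur, a step of similar or larger size toward a higher number is expected, a 1.3-fold higher number from compound 1 to compound 4 (0.10 log units; within the scatter). Compound 4 is therefore estimated at 50000 nM, between 25000 nM and 100000 nM, with a fair chance that only a limit is reported.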

Compound 4, half-maximal inhibitory concentration: > 50000 nM
Compound 4 gave a limit, no number; the forecaster's own chance of this, stated with the estimate: 55%; the middle value sits exactly at the limit.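

In this assay compound 4 gives > 50000 nM, which is a limit and not a number. As far as these compounds go, the step is an at least 1.2-fold higher number from compound 1 to compound 4 (0.10 log units; that floor lies within the scatter), so a second small group without a ring of carbon atoms in place of 2,6-dichlorophenyl also yields no number, though the size of the change stays unknown. The step between vinyl and cyclopropyl cannot be read, and the limit now takes in more of the series: the limit of > 50000 nM in this assay, at which 2 of the 4 values shown sit.

From the compounds shown here alone, whether an amine or a longer chain on this saturated chain carbon would give a number remains open. So does the true size of the values of compound 3 and compound 4.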